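The compounds below may be only part of what the source reports. "The series", "measured", "known", "first", "only" and "open" are said of these compounds alone.

Compound 1 `O=C1c2c[n+]([O-])c3ccccc3c2C(=O)c2[nH]c3ccccc3c21` is the bare core, and in a toxicity assay on L02 cells (Homo sapiens) for cytotoxicity, read by MTT assay, with a stated time of 72 h (a higher number here means a weaker inhibitor, a lower number a stronger inhibitor), compound 1 gives 400 nM. Compound 2 `CCCCN1CCN(CCCCn2c3c(c4ccccc42)C(=O)c2c[n+]([O-])c4ccccc4c2C3=O)CC1` adds a long substituted chain to that core, and in this assay compound 2 gives 5690 nM, the higher of the two numbers, separated from compound 1 by a gap beyond the usual scatter. Compound 3 `O=C1c2c[n+]([O-])c3ccccc3c2C(=O)c2c1c1ccccc1n2CCCN1CCC(O)CC1` differs from compound 2 in a single place: 4-hydroxypiperidin-1-yl in place of (4-butylpiperazin-1-yl)methyl on a saturated chain carbon, three bonds along the chain from an aromatic nitrogen. Among the compounds with values here, no pair of measured compounds shows this particular change, so its effect can only be guessed from the two values at hand. Compound 3 is expected to give 4000 nM, with a likely range from 1500 nM to 12000 nM. That estimate means a step of a 1.4-fold lower number from compound 2 to compound 3 (0.15 log units; within the scatter), expected to be small, toward a lower number, and not clearly beyond the scatter.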

Compound 3, half-maximal inhibitory concentration: 120 nM
Beside the measured number, compound 3's estimate is 33-fold (1.52 log units) above it; the measured number lies below the stated range.
By their numbers in this assay, from the lowest: compound 3; then compound 1; then compound 2.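

In this assay, the group at the end of the chain on the aromatic nitrogen proves to matter a great deal: this change brings a 47-fold lower number from compound 2 to compound 3 (1.68 log units; beyond the scatter), so what sits three bonds along the chain from that nitrogen can move the number by a large step. Compound 2 alone had suggested that a chain lifts the number above that of the bare core, yet 3-(4-hydroxypiperidin-1-yl)propyl in place of hydrogen gives a 3.3-fold lower number from compound 1 to compound 3 (0.52 log units; beyond the scatter), so carrying a chain does not by itself raise it. Nothing measured here says why these two end groups differ so much.

Still open, as far as these compounds go, is which part of the change carries the step: the added hydroxyl group, or the loss of the butyl group and the second ring nitrogen. A plain piperidine or a morpholine on the same propyl chain would help to separate these.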